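Replacing azetidin-1-yl with (4-bromophenyl)amino on the shared core

A few compounds are considered here, and "the series" means these few. Any claim that something is new, unique, unknown or untested is made for them only; others in the source may bear on it.

In a functional assay on MGC-803 cells (Homo sapiens) for inhibition, read by sulforhodamine B assay (a higher number here means a weaker inhibitor, a lower number a stronger inhibitor), compound 1 `O=C1C=C(N2CCC2)C(=O)c2c1nc1n2[C@H]2OC[C@@H](O)[C@H]2OC1` gives > 16000 nM, which is a limit and not a number. Compound 3 `O=C1C(N2CCCC2)=CC(=O)c2c1nc1n2[C@H]2OC[C@@H](O)[C@H]2OC1` gives > 16000 nM, also a limit. Among the compounds with values here, compound 2 `Cc1ccc(NC2=CC(=O)c3c(nc4n3[C@H]3OC[C@@H](O)[C@H]3OC4)C2=O)cc1C` gives 1050 nM, the only true number so far. Compound 1 therefore stands at the limit of > 16000 nM in this assay, at which 2 of the 3 values shown sit, and any step from it starts without an exact value.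

The change to compound 4 `O=C1C=C(Nc2ccc(Br)cc2)C(=O)c2c1nc1n2[C@H]2OC[C@@H](O)[C@H]2OC1` is (4-bromophenyl)amino in place of azetidin-1-yl on a double-bonded ring carbon.

Within the data shown here, one measured step bears on this change: an at least 15-fold higher number from compound 2 to compound 3 (1.18 log units; beyond the scatter). That step is large and beyond the scatter, with pyrrolidin-1-yl in place of (3,4-dimethylphenyl)amino. The change to compound 4 runs the opposite way, with a phenyl-bearing amino group entering and a non-aromatic ring leaving. The groups in that pair differ from those here, so the transfer is loose and the range must stay wide. A large move toward a lower number, meaning a stronger inhibitor, is expected in this assay. The estimated step is an at least 10-fold lower number from compound 1 to compound 4 (1.02 log units; beyond the scatter). Compound 4 is estimated at 1500 nM, with an expected range of 400 nM to 6000 nM.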

Compound 4, half-maximal inhibitory concentration: 1010 nM
Compound 4: middle estimate off by 1.5-fold (0.17 log units), on the high side, and the stated range covers the measured number.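

In this assay, the exchange on the double-bonded ring carbon gives an at least 15-fold lower number from compound 1 to compound 4 (1.19 log units; beyond the scatter), so a large step that had been seen with other groups, and in the opposite direction, now also appears with a phenyl-bearing amino group entering on the core of compound 1. Going by these compounds, compound 1 gives > 16000 nM, which is a limit and not a number, so the true size of this step remains unknown and only its lower bound is read. Across the four compounds shown, compound 2 and compound 4, which carry an aromatic ring on the amino group, give true numbers, no compound goes against the split, and compound 1 and compound 3, with azetidin-1-yl and pyrrolidin-1-yl, sit together at one end of the scale: the limit of > 16000 nM in this assay, at which 2 of the 4 values shown sit.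

The compounds shown leave open whether the step follows the aromatic ring, the bromine or the amino hydrogen, as these enter together in this single change. A plain phenylamino group, a benzylamino group or an open-chain amine such as dimethylamino on the same carbon would begin to separate these parts.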